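Three amide variants tolerated at the assay limit, a fourth to follow

This account rests on a few compounds, and the source may have more. Where it says the series, first, only, none or still open, it means among the compounds named here.

Compound 1 `COc1ccc(-c2cnc(NC(=O)C3CCCC3)n2C)cc1`: in a toxicity assay on THP-1 cells (Homo sapiens) for inhibition (a lower number here means that less compound is tolerated, a higher number that more compound is tolerated), compound 1 gives > 100000 nM, which is a limit of the assay.
Compound 2 `COc1ccc(-c2cnc(NC(=O)CCc3ccccc3)n2C)cc1`: in this assay compound 2 gives > 100000 nM, again a limit.
Compound 3 `COc1ccc(-c2cnc(NC(=O)c3cccc(C#N)c3)n2C)cc1`: in this assay compound 3 gives > 100000 nM, also a limit.

Compound 3 therefore stands only at a limit, and both other compounds stand at the same limit (the limit of > 100000 nM in this assay, at which 3 of the 3 values shown sit). The measured steps a step that the two limits leave unreadable from compound 1 to compound 2, a step that the two limits leave unreadable from compound 1 to compound 3 and a step that the two limits leave unreadable from compound 2 to compound 3 are all unreadable in size. Compound 4 `COc1ccc(-c2cnc(NC(=O)c3ccc(F)cc3)n2C)cc1` differs from compound 3 by 4-fluorophenyl in place of 3-cyanophenyl on a carbonyl carbon. Among the compounds with values here, nothing among the measured steps separates these compounds, so no step beyond the scatter is expected; the step that the limit leaves unreadable from compound 3 to compound 4 is estimated as flat. Compound 4 is expected to give about 150000 nM, between 50000 nM and 500000 nM, most likely again only a limit.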

Compound 4, half-maximal cytotoxic concentration: >= 50000 nM
Compound 4 was reported as a limit; the forecaster's own chance of this, stated with the estimate: 85%; the middle value lies beyond the limit too.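

Compound 4, like compound 1, compound 2 and compound 3, is known only as a limit, so no step among these four compounds can be read. The compounds shown leave open whether any of these amides differs from another in this assay.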